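Replacing the side chain of compound 1 with an oxadiazole

A few compounds are considered here, and "the series" means these few. Any claim that something is new, unique, unknown or untested is made for them only; others in the source may bear on it.

compound 1 `C/C(=N\NC(=N)N)c1sc(-c2ccc(-c3ccccc3)cc2)nc1C` gives 2700 nM
compound 2 `Cc1nc(-c2ccc(-c3ccccc3)cc2)sc1-c1ccnc(NC(=N)N)n1` gives 2200 nM
compound 3 `Cc1nc(-c2ccc(-c3ccccc3)cc2)sc1-c1nnc(N2CC(O)C2)o1` gives 150000 nM

In a physicochemical assay for solubility, in phosphate buffer, with a stated time of 2 h (a higher number here means a more soluble compound, a lower number a less soluble compound), compound 1 reads 2700 nM and lies within the usual scatter of compound 2, while compound 3 stands beyond the scatter above both. The next compound to be measured is compound 4 `Cc1nc(-c2ccc(-c3ccccc3)cc2)sc1-c1nnc(NN)o1`, which differs from compound 1 in one place: a group of 7 heavy atoms (2 carbon, 4 nitrogen, 1 oxygen; one five-membered aromatic ring with 3 hetero atoms) in place of a group of 7 heavy atoms (3 carbon, 4 nitrogen; no ring), on an aromatic carbon. The entering group, 5-(aminoamino)-1,3,4-oxadiazol-2-yl, sits on an aromatic carbon, next to the ring sulfur. Within the data shown here, no measured pair isolates this change, so its size cannot be read directly. Among the measured compounds shown here, the only guide is compound 3 at 150000 nM, which also carries a five-membered aromatic ring with 3 hetero atoms at this place. One compound is thin evidence, so only part of that gap is expected to carry over. The expected change in this assay is upward and modestly beyond the scatter, an estimated 3.3-fold higher number from compound 1 to compound 4 (0.52 log units; beyond the scatter), with wide uncertainty. Compound 4 is expected at 9000 nM, within an estimated range of 2000 nM to 50000 nM.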

Compound 4, solubility: 77000 nM
For compound 4 the middle estimate is 8.6-fold (0.93 log units) below the measured one, outside the stated range (above it).
By their numbers in this assay, from the lowest: compounds 2 and 1 (each within the scatter of the next); then compounds 4 and 3 (each within the scatter of the next).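

In this assay the 5-(aminoamino)-1,3,4-oxadiazol-2-yl group on this aromatic carbon gives the first direct measure of replacing the ringless side chain of compound 1 with a five-membered aromatic ring with 3 hetero atoms, a large step beyond the scatter (a 29-fold higher number from compound 1 to compound 4 (1.46 log units; beyond the scatter)). The group carried on that ring makes no difference that can be read here, as aminoamino in place of 3-hydroxyazetidin-1-yl stays within the scatter (a 1.9-fold lower number from compound 3 to compound 4 (0.29 log units; within the scatter)). No measurement shown gives a reason for the large step.

It remains open whether the oxadiazole alone accounts for this step or whether its substituent contributes, since a plain amine or a methyl group on that ring is not among the compounds shown. From the compounds shown here alone, whether a thiadiazole at this place would read the same also remains open.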